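A Fluoro-for-Nitro Swap on a Weakly Active Series

The source may report more compounds than this note shows. Statements on the series, on what has been measured and on what is new or still open speak of the compounds shown alone.

Of the compounds shown here, three built on one shared core have been tested. Compound 1 `CCOC(=O)C1=Cc2ccccc2OC1(OCc1cn(-c2ccc(C)cc2)nn1)C(F)(F)F` gives 30200 nM in a functional assay on DU-145 cells (Homo sapiens) for inhibition, read by MTT assay, with a stated time of 24 h; a lower number here means a stronger inhibitor, a higher number a weaker inhibitor. Compound 2 `O=C(O)C1=Cc2ccccc2OC1(OCc1cc(-c2ccc([N+](=O)[O-])cc2)no1)C(F)(F)F` gives 100000 nM in this assay. For compound 3 `CCOC(=O)C1=Cc2ccccc2OC1(OCc1cc(-c2ccc([N+](=O)[O-])cc2)no1)C(F)(F)F` this assay returns only a limit, > 150000 nM, so compound 3 stands at the weak end of what was measured without a firm number. Among the compounds with values here, the single measured step, an at least 1.5-fold higher number from compound 2 to compound 3 (0.17 log units; that floor lies within the scatter), alters the ester end of the molecule, and the limit of > 150000 nM in this assay, at which 1 of the 3 values shown sits, marks where compound 3 sits.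

Compound 4 `CCOC(=O)C1=Cc2ccccc2OC1(OCc1cc(-c2ccc(F)cc2)no1)C(F)(F)F` differs from compound 3 in one place: fluoro in place of nitro on an aromatic carbon. Within the data shown here, no measured step touches this group, so nothing among the measurements points to a direction or size for it. Compound 4 is therefore expected to stay weak, around 100000 nM, with a range from 30000 nM to 300000 nM. That expectation amounts to an at least 1.5-fold lower number from compound 3 to compound 4 (0.17 log units; that floor lies within the scatter).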

Compound 4, half-maximal inhibitory concentration: 53500 nM
For compound 4 the middle estimate is 1.9-fold (0.27 log units) above the measured one; the range from low to high includes it.
By their numbers in this assay, from the lowest: compounds 1, 4 and 2 (each within the scatter of the next, the first and the last beyond it). At a limit, above all of these: compound 3.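

Within the data shown here, until now no step touched this aromatic carbon, para to a large group. Going from 4-nitrophenyl to 4-fluorophenyl gives an at least 2.8-fold lower number from compound 3 to compound 4 (0.44 log units; beyond the scatter), so in this assay this position does respond to a change of group. Compound 3 has only a limit, so the true size of the step remains unknown and this figure is a floor: the limit of > 150000 nM in this assay, at which 1 of the 4 values shown sits.

On these data alone, whether an amine or a methoxy group at this position would move the number further remains open. Also open, as far as these compounds go, is whether the same swap would give a similar step on compound 2, which carries the carboxylic acid.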